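Compound 1 Without Its (4-Chlorophenyl)carbonyl Group

The source may report more compounds than this note shows. Statements on the series, on what has been measured and on what is new or still open speak of the compounds shown alone.

Measured so far:
compound 1, `O=C(Nc1ccccc1O)C1CCc2ccccc2N1C(=O)c1ccc(Cl)cc1`, 25100 nM
compound 2, `O=C(Nc1ccccc1C(F)(F)F)C1CCc2ccccc2N1C(=O)c1ccc(Cl)cc1`, 786 nM

Both compounds were tested in a functional assay on PC-3 cells (Homo sapiens) for cytotoxicity, read by sulforhodamine B assay, with a stated time of 72 h; a higher number here means a weaker inhibitor of growth, a lower number a stronger inhibitor of growth. Of the two numbers, compound 1 has the highest, so it is the weaker inhibitor of growth in this pair. Among the measured compounds shown here, its only neighbour is compound 2, and the single measured step, a 32-fold lower number from compound 1 to compound 2 (1.50 log units; beyond the scatter), shows how much the number moves when the group on an aromatic carbon of the amide-bearing ring is exchanged.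

Compound 3, `O=C(Nc1ccccc1O)C1CCc2ccccc2N1`, differs from compound 1 in another place entirely: hydrogen in place of (4-chlorophenyl)carbonyl on a nitrogen on an aromatic ring in a ring. For the measured compounds named here, no measured step touches this ring nitrogen, and the one step on record concerns a different part of the shared core, so it does not bear on this change. What is removed is a large piece of the molecule, and the step in this assay is therefore expected to go toward a higher number, with its size uncertain. For compound 3 the expected value is 60000 nM, in the range 15000 nM to 200000 nM. That expectation amounts to a 2.4-fold higher number from compound 1 to compound 3 (0.38 log units; beyond the scatter).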

Compound 3, concentration for 50% growth inhibition: 4310 nM
Estimate against measurement, compound 3: 14-fold (1.14 log units) above, and the stated range ends above it.
By their numbers in this assay, from the lowest: compound 2; then compound 3; then compound 1.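

Among the compounds shown here, replacing the (4-chlorophenyl)carbonyl group on the nitrogen with hydrogen gives a 5.8-fold lower number from compound 1 to compound 3 (0.77 log units; beyond the scatter) in this assay and is the first measured change at this place on the shared core. With hydroxy on the aromatic carbon, as in compound 1 and compound 3, growth inhibition therefore does not depend on this large piece, which holds an entire six-membered aromatic ring and a chlorine, and the number in fact improves when it is gone. No measurement shown here explains why the loss of so many atoms leads to stronger inhibition of growth.

The compounds shown leave open whether the same removal would move the number in the same direction with trifluoromethyl in place of hydroxy on the aromatic carbon, since this single step was read only on the hydroxy compounds. They also leave open how the number would respond to other groups on this nitrogen, such as methyl, acetyl or a benzoyl group without its chlorine, and so whether hydrogen is the best choice here or simply the only alternative seen so far.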